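From 2-fluorophenyl to 4-chlorophenyl on a shared core

The source may report more compounds than this note shows. Statements on the series, on what has been measured and on what is new or still open speak of the compounds shown alone.

Three measured compounds share one core and differ only in the aromatic group attached to it. In a functional assay on B16 cells (Mus musculus) for cytotoxicity, read by CCK-8 assay, with a stated time of 24 h (on this read-out higher numbers stand for weaker inhibition and lower numbers for stronger inhibition), compound 1 `COc1ccccc1Oc1c(N)nc(-c2ccccc2)nc1OCCO` gives 31100 nM. Compound 2 `COc1cccc(-c2nc(N)c(Oc3ccccc3OC)c(OCCO)n2)c1` gives 30500 nM. Compound 3 `COc1ccccc1Oc1c(N)nc(-c2ccccc2F)nc1OCCO` gives 11800 nM, the lowest number of the three and so the strongest inhibition in this small set.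

The next compound to be tested is compound 4 `COc1ccccc1Oc1c(N)nc(-c2ccc(Cl)cc2)nc1OCCO`. In it, 4-chlorophenyl takes the place of 2-fluorophenyl on an aromatic carbon between two ring nitrogen atoms: 4-chlorophenyl in place of 2-fluorophenyl on an aromatic carbon.

The measured steps offer only partial guidance. Methoxy in place of hydrogen on an aromatic carbon gave a 1.0-fold lower number from compound 1 to compound 2 (0.01 log units; within the scatter). Fluoro in place of hydrogen gave a 2.6-fold lower number from compound 1 to compound 3 (0.42 log units; beyond the scatter), and 2-fluorophenyl in place of 3-methoxyphenyl gave a 2.6-fold lower number from compound 2 to compound 3 (0.41 log units; beyond the scatter). Among the measured compounds shown here, no measured compound carries a chloro group, so its effect here is unknown. The fluoro group that came with a 2.6-fold lower number from compound 1 to compound 3 (0.42 log units; beyond the scatter) is absent from compound 4, so a small move back toward the higher numbers seems most likely. The expected change is a 1.4-fold higher number from compound 3 to compound 4 (0.16 log units; within the scatter), a step that may not clear the usual scatter. For compound 4 the estimated value is 17000 nM, with an expected range of 7000 nM to 38000 nM.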

Compound 4, half-maximal inhibitory concentration: 7740 nM
Compound 4: middle estimate off by 2.2-fold (0.34 log units), on the high side, and the stated range covers the measured number.
By their numbers in this assay, from the lowest: compounds 4 and 3 (each within the scatter of the next); then compounds 2 and 1 (each within the scatter of the next).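

Placing a chlorine on the phenyl ring is enough to move the number beyond the scatter in this assay, with a 4.0-fold lower number from compound 1 to compound 4 (0.60 log units; beyond the scatter) for 4-chlorophenyl in place of phenyl, and a 3.9-fold lower number from compound 2 to compound 4 (0.60 log units; beyond the scatter) when 4-chlorophenyl takes the place of 3-methoxyphenyl. So the gain seen with 2-fluorophenyl is not unique to that group, since a 1.5-fold lower number from compound 3 to compound 4 (0.18 log units; within the scatter) leaves these two halogen-bearing aryl groups indistinguishable at this position, and both stand apart from phenyl, while 3-methoxyphenyl does not. No measurement here gives a reason for this difference.

The compounds shown cannot separate the kind of halogen from its place on the ring, a question that 4-fluorophenyl and 2-chlorophenyl on the same core would address. From the compounds shown here alone, it also remains open how this position responds to a phenyl ring carrying an amine or a carboxylic acid, groups quite unlike the halogens and the methoxy group seen so far.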